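Moving a Trifluoromethyl Group on the Sulfonyl Aryl Ring

The source may report more compounds than this note shows. Statements on the series, on what has been measured and on what is new or still open speak of the compounds shown alone.

Measured in a functional assay on LNCaP cells (Homo sapiens) for antiproliferative activity, read by propidium iodide staining, with a stated time of 96 h; on this read-out higher numbers stand for weaker inhibition and lower numbers for stronger inhibition:
- compound 1 `CC(O)(CS(=O)(=O)c1cccc(S(F)(F)(F)(F)F)c1)C(=O)Nc1ccc(S(F)(F)(F)(F)F)cc1`: 31300 nM
- compound 2 `CC(O)(CS(=O)(=O)c1ccc(C(F)(F)F)cc1)C(=O)Nc1ccc(S(F)(F)(F)(F)F)cc1`: 20700 nM

In this assay compound 2 gives 20700 nM, and compound 1 gives 31300 nM. These two values lie within the scatter of each other, so the numbers do not rank compound 2 against compound 1.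

The next compound is compound 3 `CC(O)(CS(=O)(=O)c1cccc(C(F)(F)F)c1)C(=O)Nc1ccc(S(F)(F)(F)(F)F)cc1`, which has the same atoms as compound 2, joined differently. The difference is 3-(trifluoromethyl)phenyl in place of 4-(trifluoromethyl)phenyl on a sulfonyl sulfur.

For the measured compounds named here, no measured pair differs in one place, so the data give no direct measure of what such a change does. With nothing to suggest a direction, no step beyond the scatter is expected in this assay, and the estimate stays close to compound 2 at 20700 nM. The expected change is small, namely a 1.1-fold higher number from compound 2 to compound 3 (0.03 log units; within the scatter). For compound 3 the estimated value is 22000 nM, with an expected range from 10000 nM to 45000 nM.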

Compound 3, half-maximal inhibitory concentration: 21000 nM
Compound 3: the middle estimate sits 1.0-fold (0.02 log units) above what was measured; the measured number falls inside the stated range.
By their numbers in this assay, from the lowest: compounds 2, 3 and 1 (each within the scatter of the next).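

In this assay the swap of 3-(trifluoromethyl)phenyl for 4-(trifluoromethyl)phenyl on a sulfonyl sulfur can now be read directly: it amounts to a 1.0-fold higher number from compound 2 to compound 3 (0.01 log units; within the scatter) and so does not tell these two isomers apart. The set also gains a second pair that differs in one place, in which a group of 4 heavy atoms (1 carbon, 3 fluorine) stands in place of a group of 6 heavy atoms (5 fluorine, 1 sulfur) on an aromatic carbon; this gives a 1.5-fold lower number from compound 1 to compound 3 (0.17 log units; within the scatter) and does not separate those two compounds either. No measurement at hand offers an explanation for either result. 

Going by these compounds, what a nitrile, a methoxy group or an amine would do on this aryl ring in this assay remains open, and so does whether any such group would give a step beyond the scatter. Also open, on these data alone, is what would follow if a pyridine ring took the place of the phenyl ring on the sulfonyl sulfur, or if a thioether took the place of the sulfonyl group.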